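The compounds below may be only part of what the source reports. "The series", "measured", "known", "first", "only" and "open" are said of these compounds alone.

Measured compounds:
compound 1 `COC(=O)c1ccc(-c2cnc(C(O)CCc3ccc(-c4ccccc4)cc3)o2)nc1` – 1100 nM
compound 2 `COC(=O)c1ccc(-c2cnc(C(=O)CCc3ccc(-c4ccccc4)cc3)o2)nc1` – 2.2 nM
compound 3 `O=C(O)c1cc(-c2cnc(C(=O)CCc3ccc(-c4ccccc4)cc3)o2)ccn1` – 50 nM

In an assay for inhibition of Fatty-acid amide hydrolase 1 (Rattus norvegicus) (on this read-out higher numbers stand for weaker inhibition and lower numbers for stronger inhibition), compound 3 stands second highest of the three numbers; its nearest neighbour is compound 1 with 1100 nM, and compound 2 with 2.2 nM lies furthest away. The step of a 23-fold higher number from compound 2 to compound 3 (1.36 log units; beyond the scatter) shows how strongly the aromatic group on the shared core shifts this assay.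

Compound 4 `O=C(CCc1ccc(-c2ccccc2)cc1)c1ncc(C(=O)C(F)(F)F)o1` follows from compound 3 by (trifluoromethyl)carbonyl in place of 2-carboxypyridin-4-yl on an aromatic carbon. Among the measured compounds shown here, no measured step exchanges that aromatic group for a group without a ring, so only the step from compound 2 to compound 3 bears on it, and it bears only loosely: it shows that this position tolerates a large shift in either direction. The shift expected here is a 1.2-fold higher number from compound 3 to compound 4 (0.08 log units; within the scatter), with wide uncertainty. Compound 4 is therefore estimated at 60 nM, within a range from 8 nM to 500 nM.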

Compound 4, inhibition constant: 8 nM
Beside the measured number, compound 4's estimate is 7.5-fold (0.88 log units) above it; measured number inside the range.
By their numbers in this assay, from the lowest: compound 2; then compound 4; then compound 3; then compound 1.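

In this assay, (trifluoromethyl)carbonyl on this aromatic carbon, next to the ring oxygen, gives a 6.3-fold lower number from compound 3 to compound 4 (0.80 log units; beyond the scatter), so a group with no ring can replace 2-carboxypyridin-4-yl here without a loss of inhibition. It does not match 5-(methoxycarbonyl)pyridin-2-yl, however, as the change gives a 3.6-fold higher number from compound 2 to compound 4 (0.56 log units; beyond the scatter). The earlier compounds compared only two ring-bearing groups at this position, whereas the ringless group now falls between them, so among these three groups the presence of a ring does not by itself set the order. Nothing available here accounts for these shifts. As far as these compounds go, it remains open whether a nitrile, a carboxylic acid or a methyl ester attached directly at this carbon, with no ring, would give a number nearer that of compound 2 or that of compound 3.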